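A few compounds are considered here, and "the series" means these few. Any claim that something is new, unique, unknown or untested is made for them only; others in the source may bear on it.

Three compounds share one core and differ only in the group on a single aromatic carbon of that core:

compound 1, `Cc1nc2cc(-c3c[nH]nc3C)sc2c(=O)[nH]1`: 1500 nM
compound 2, `Cc1n[nH]cc1-c1cc2nc(C3CCCCC3)[nH]c(=O)c2s1`: 940 nM
compound 3, `Cc1n[nH]cc1-c1cc2nc(-c3ccccc3)[nH]c(=O)c2s1`: 1600 nM

All three values come from an assay for inhibition of Rho-associated protein kinase 1 (Homo sapiens), read by TR-FRET, with stated times of 5 min and 2 h; on this read-out higher numbers stand for weaker inhibition and lower numbers for stronger inhibition. Compound 1 carries methyl at the varied carbon. The step of a 1.6-fold lower number from compound 1 to compound 2 (0.20 log units; within the scatter) puts cyclohexyl there, and the step of a 1.1-fold higher number from compound 1 to compound 3 (0.03 log units; within the scatter) puts phenyl there. Between the two larger groups the step is a 1.7-fold higher number from compound 2 to compound 3 (0.23 log units; within the scatter). Each of these steps lies within the usual scatter of repeated measurements, so compound 3 cannot be told apart from compound 1 or compound 2 on these numbers; so far the identity of the group at this carbon has made no detectable difference in this assay.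

Compound 4 is `Cc1n[nH]cc1-c1cc2nc(CN3CCCCC3)[nH]c(=O)c2s1`. The change from compound 3 is (piperidin-1-yl)methyl in place of phenyl on an aromatic carbon. Among the compounds with values here, no measured step introduces a group of this kind, so the only guide is the run of three exchanges at the same carbon, none of which moved this assay beyond the scatter. On that basis the step from compound 3 to compound 4 is expected to be a 1.3-fold lower number from compound 3 to compound 4 (0.12 log units; within the scatter), with no movement beyond the scatter in either direction. The estimate for compound 4 in this assay is 1200 nM, expected to fall between 400 nM and 4000 nM.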

Compound 4, half-maximal inhibitory concentration: 200 nM
Beside the measured number, compound 4's estimate is 6.0-fold (0.78 log units) above it; measured number below the stated range.
By their numbers in this assay, from the lowest: compound 4; then compounds 2, 1 and 3 (each within the scatter of the next).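

In this assay this carbon, between two ring nitrogen atoms, proves sensitive to what it carries: methyl, cyclohexyl and phenyl could not be told apart, but (piperidin-1-yl)methyl stands clear of all three, with an 8.0-fold lower number from compound 3 to compound 4 (0.90 log units; beyond the scatter) and a 4.7-fold lower number from compound 2 to compound 4 (0.67 log units; beyond the scatter) and also a 7.5-fold lower number from compound 1 to compound 4 (0.88 log units; beyond the scatter) on the same read-out. The comparison with compound 1 reads as piperidin-1-yl in place of a hydrogen on the methyl group, while the comparison with compound 2 shows that a six-membered ring alone does not match this result, since the entering group differs from cyclohexyl in both its ring nitrogen and its one-carbon link to the core. Nothing available explains the stronger inhibition by compound 4.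

These compounds leave open whether the ring nitrogen, the one-carbon link or the two together matter, and cyclohexylmethyl, which keeps the link without the nitrogen, would help to separate them. As far as these compounds go, it also remains open how far the result extends to other amines, such as morpholin-4-ylmethyl or dimethylaminomethyl, or to a longer chain carrying the piperidine.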